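Compound 2 to compound 3: a sec-butyl isomer swap

The compounds below may be only part of what the source reports. "The series", "measured", "known", "first", "only" and "open" are said of these compounds alone.

Compound 2 (`CCC(C)NC(=O)CCC(=O)c1cccc(C(F)(F)F)c1`) gives > 200 mg/kg in a functional assay on the whole organism with Mus musculus as the target (a higher number here means that more compound is needed for the effect, a lower number that less compound is needed), and this is a limit, not a number. Compound 1 (`CN(C)C(=O)CCC(=O)c1cccc(C(F)(F)F)c1`) gives > 50 mg/kg in this assay, also a limit. Compound 2 therefore has no measured potency to build on, only a limit.

The next compound, compound 3 (`CC(C)CNC(=O)CCC(=O)c1cccc(C(F)(F)F)c1`), carries isobutyl in place of sec-butyl on an amide-type nitrogen. The two have the same atoms, joined differently.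

Going by the values given here, the only measured step that bears on this is a step that the two limits leave unreadable from compound 1 to compound 2, at the same nitrogen, and it gives no usable size. With no size to carry over, no shift beyond the scatter is expected in this assay, in either direction, and another limit is a likely outcome. The expected step is a number no higher from compound 2 to compound 3 (the limit leaves the size open). For compound 3 the estimated value is 200 mg/kg, with an expected range of 80 mg/kg to 500 mg/kg.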

Compound 3, dose for half-maximal effect: > 200 mg/kg
Compound 3 was reported as a limit (the forecaster's own chance of this, stated with the estimate: 65%); the middle value lies on the limit itself.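

Compound 3 is reported only as a limit in this assay, so no step can be read among compound 1, compound 2 and compound 3. Going by these compounds, the actual doses of all three, and how the groups on the amide-type nitrogen rank against one another, remain open.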